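The source may report more compounds than this note shows. Statements on the series, on what has been measured and on what is new or still open speak of the compounds shown alone.

Working notes on the series, read in an ADME assay (liver) for metabolic stability, with Liver microsome (Rattus norvegicus) as the target, using microsomes and NADPH, with a stated time of 30 min, at 37 degrees C, tested at 1 uM; a lower number here means slower removal, a higher number faster removal of the compound. Compound 1 `CC(O)(c1ccc(-c2ccc(S(=O)(=O)c3ccc(N)nc3)nc2Oc2ccccc2)nc1)C(F)(F)F` gives 213 mL.min-1.g-1, a measured number. Compound 2 `CC(O)(c1ccc(-c2ncc(S(=O)(=O)c3ccc(N)nc3)s2)c(Cl)c1)C(F)(F)F` gives < 14 mL.min-1.g-1, which is a limit of the assay and not a number. Compound 2 therefore stands at the limit of < 14 mL.min-1.g-1 in this assay, at which 1 of the 2 values shown sits. Among the measured compounds shown here, compound 1 and compound 2 differ in more than one place, so their readings supply no measured step for the change considered here.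

Compound 3 `C[C@](O)(CO)c1ccc(-c2ncc(S(=O)(=O)c3ccc(N)nc3)s2)c(Cl)c1` keeps the shared core of compound 2 and carries 1-hydroxy-1-(hydroxymethyl)ethyl in place of 1-hydroxy-1-(trifluoromethyl)ethyl on an aromatic carbon, meta to a chloro group (1-hydroxy-1-(hydroxymethyl)ethyl in place of 1-hydroxy-1-(trifluoromethyl)ethyl on an aromatic carbon). For the measured compounds named here, no measured pair shows this replacement, so the expectation is a cautious one, and the chloro group and the rest of the molecule stay as they are. In this assay, the estimated change is a number no lower from compound 2 to compound 3 (the limit leaves the size open), expected to remain within the usual scatter of repeated measurements. A report of compound 3 as a limit alone is also quite likely. For compound 3 the expected value is 14 mL.min-1.g-1, with an estimated range of 7 mL.min-1.g-1 to 35 mL.min-1.g-1.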

Compound 3, intrinsic clearance in microsomes: < 14 mL.min-1.g-1
Compound 3: a limit, no number; the forecaster's own chance of this, stated with the estimate: 60%; the middle value lies on the limit itself.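

Compound 2 and compound 3 are both reported as limits of the assay and not as numbers, and no step can be read between them. The compounds shown leave open the size and direction of any change in intrinsic clearance when 1-hydroxy-1-(hydroxymethyl)ethyl takes the place of 1-hydroxy-1-(trifluoromethyl)ethyl.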